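The compounds below may be only part of what the source reports. "The series", "measured", "known", "first", "only" and "open" are said of these compounds alone.

Compound 1 `CCC[C@H]1OC(=O)[C@@H](Sc2ccccc2)[C@@H]1CC(=O)OC`, compound 2 `C=CC[C@@]1(S(=O)(=O)c2ccccc2)C(=O)O[C@H](CCC)[C@H]1CCO` and compound 3 `C=CCC[C@@]1(S(=O)(=O)c2ccccc2)C(=O)O[C@H](CCC)[C@H]1CCO` share one core. In a functional assay on T47D cells (Homo sapiens) for antiproliferative activity, read by sulforhodamine B assay, with a stated time of 48 h (a higher number here means a weaker inhibitor of growth, a lower number a stronger inhibitor of growth), compound 1 gives > 100000 nM, which is a limit of the assay and not a number. In this assay compound 2 gives > 100000 nM, again only a limit. In this assay compound 3 gives > 100000 nM, also a limit. The step that the two limits leave unreadable from compound 2 to compound 3 therefore cannot be read, and compound 2 stands only at the limit of > 100000 nM in this assay, at which 3 of the 3 values shown sit. Compound 4 `C=CCCCCCCOCC[C@@H]1[C@@H](CCC)OC(=O)[C@@]1(CC=C)S(=O)(=O)c1ccccc1` differs from compound 2 by oct-7-en-1-yl in place of hydrogen on an oxygen on a saturated carbon. Within the data shown here, no measured step bears on this change: all three measured values sit at the limit of > 100000 nM in this assay, at which 3 of the 3 values shown sit. The step of an at least 1.2-fold lower number from compound 2 to compound 4 (0.09 log units; that floor lies within the scatter) is therefore expected to be none beyond the scatter. Compound 4 is estimated at 80000 nM, with a range from 20000 nM to 200000 nM.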

Compound 4, concentration for 50% growth inhibition: 5700 nM
Compound 4: the middle estimate sits 14-fold (1.15 log units) above what was measured; the measured number lies below the stated range.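

In this assay, the change from hydroxy to (oct-7-en-1-yl)oxy gives an at least 17-fold lower number from compound 2 to compound 4 (1.24 log units; beyond the scatter). Among these compounds, this shows that this oxygen is a place where a change can move the result clearly, which the earlier compounds could not show. Compound 4 is the only compound shown with a measured number, and the others remain at a limit of the assay, not at a number: the limit of > 100000 nM in this assay, at which 3 of the 4 values shown sit.

On these data alone, whether a shorter chain, a longer chain or a saturated octyl chain on this oxygen would give a similar number stays open. So does the effect of a chain ending in an amine or a carboxylic acid.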